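The source may report more compounds than this note shows. Statements on the series, on what has been measured and on what is new or still open speak of the compounds shown alone.

Measured so far in a functional assay on MCF7 cells (Homo sapiens) for inhibition, read by CCK-8 assay; on this read-out higher numbers stand for weaker inhibition and lower numbers for stronger inhibition:
compound 1 `Oc1ccccc1/C=N/c1nnc(SCc2nnc(-c3ccccc3Cl)o2)s1` gives 18100 nM
compound 2 `Oc1ccccc1/C=N/c1nnc(SCc2nnc(-c3ccc(Cl)cc3)o2)s1` gives 7550 nM
compound 3 `Cc1ccc(-c2nnc(CSc3nnc(/N=C/c4ccccc4O)s3)o2)cc1` gives 8750 nM

Compound 2 carries the lowest of the three numbers; toward compound 3 the gap is a 1.2-fold higher number from compound 2 to compound 3 (0.06 log units; within the scatter), toward compound 1 it is a 2.4-fold lower number from compound 1 to compound 2 (0.38 log units; beyond the scatter).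

Compound 4 `O=[N+]([O-])c1cccc(-c2nnc(CSc3nnc(/N=C/c4ccccc4O)s3)o2)c1` differs from compound 2 as follows: 3-nitrophenyl in place of 4-chlorophenyl on an aromatic carbon. The steps on hand all alter this same aryl ring on the shared core: a 2.4-fold lower number from compound 1 to compound 2 (0.38 log units; beyond the scatter) and a 2.1-fold lower number from compound 1 to compound 3 (0.32 log units; beyond the scatter) were modest, while a 1.2-fold higher number from compound 2 to compound 3 (0.06 log units; within the scatter) stayed within the scatter. Going by the values given here, no measured step covers a 3-nitrophenyl, so the position and the group are both untested. A step of at most modest size is therefore expected in this assay, with no clear direction. For compound 4 the estimate is 10000 nM, with a range of 4000 nM to 25000 nM, meaning an expected step of a 1.3-fold higher number from compound 2 to compound 4 (0.12 log units; within the scatter).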

Compound 4, half-maximal inhibitory concentration: 13900 nM
Beside the measured number, compound 4's estimate is 1.4-fold (0.14 log units) below it; the range from low to high includes it.
By their numbers in this assay, from the lowest: compounds 2, 3, 4 and 1 (each within the scatter of the next, the first and the last beyond it).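

In this assay the 3-nitrophenyl group, which brings hydrogen-bond acceptors to this aryl position, gives no step beyond the scatter against any of the three earlier compounds (a 1.8-fold higher number from compound 2 to compound 4 (0.27 log units; within the scatter); a 1.6-fold higher number from compound 3 to compound 4 (0.20 log units; within the scatter); a 1.3-fold lower number from compound 1 to compound 4 (0.11 log units; within the scatter)). Compound 4 therefore sits within the scatter of both ends of a set whose ends differ beyond it, and it sharpens no ranking of these aryl groups. Nothing on hand gives a cause for these numbers.

On these data alone, whether an amine or a carboxylic acid on this aryl ring would give a step beyond the scatter stays open. So does the effect of changes elsewhere on the shared core.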